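The compounds below may be only part of what the source reports. "The series", "measured", "known", "first", "only" and "open" are said of these compounds alone.

Compound 3 `O=C(N/N=C/N1CCN(c2cc3c(cc2F)c(=O)c(C(=O)O)cn3C2CC2)CC1)c1cccc(C(F)(F)F)c1` is one of three close relatives examined for cytotoxicity. In an ADME assay on HepG2 cells (Homo sapiens) for cytotoxicity, read by MTT assay (on this read-out lower numbers stand for stronger inhibition and higher numbers for weaker inhibition), compound 3 gives only a limit of the assay, > 322000 nM. Compound 2 `O=C(N/N=C/N1CCN(c2cc3c(cc2F)c(=O)c(C(=O)O)cn3C2CC2)CC1)c1ccc(C(F)(F)F)cc1` carries a 4-(trifluoromethyl)phenyl group on the same carbonyl carbon, and in this assay compound 2 gives 347000 nM. The step that the limit leaves unreadable from compound 2 to compound 3 cannot be read, because the result for compound 3 is a limit, (the limit of > 322000 nM in this assay, at which 1 of the 3 values shown sits). Compound 1 `O=C(N/N=C/Nc1ccc(C(=O)O)c(O)c1)c1cccc(C(F)(F)F)c1`, built on a different core, has in this assay only the entry "not determined" (no result reported), so compound 1 contributes no number.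

Compound 4 `O=C(N/N=C/N1CCN(c2cc3c(cc2F)c(=O)c(C(=O)O)cn3C2CC2)CC1)c1ccc(F)cc1` is not yet measured. It differs from compound 3 in one place: 4-fluorophenyl in place of 3-(trifluoromethyl)phenyl on a carbonyl carbon. Among the compounds with values here, the only step among the measured compounds that touches this carbonyl position, the step from compound 2 to compound 3, has no readable size, so the measured data give no guide to the direction or size of the change. Both measured relatives sit at very weak cytotoxicity, one of them at a limit, and compound 4 is expected to stay in the same region, with the step that the limit leaves unreadable from compound 3 to compound 4 expected to be none beyond the scatter. The estimate for compound 4 in this assay is therefore 350000 nM, between 150000 nM and 1000000 nM, with a good chance that only a limit is reported.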

Compound 4, half-maximal inhibitory concentration: > 1280000 nM
Compound 4: a limit, no number (the forecaster's own chance of this, stated with the estimate: 60%); at least 3.6-fold (0.56 log units) between middle value and limit.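

Within the data shown here, at the aromatic group on the carbonyl carbon, the earlier compounds offered no readable step, and compound 4 supplies the first one: in this assay, fluoro in place of trifluoromethyl on an aromatic carbon gives an at least 3.6-fold higher number from compound 2 to compound 4 (0.56 log units; beyond the scatter). This shows that the group on this carbonyl carbon can move the read-out beyond the usual scatter, and the direction is toward weaker inhibition of the cells, so the 4-fluorophenyl compound is the less cytotoxic of this pair. The result for compound 4 is itself a limit and not a number: the limit of > 1280000 nM in this assay, at which 1 of the 4 values shown sits.

On these data alone, the steps that involve compound 3 cannot be read, so the data do not separate 3-(trifluoromethyl)phenyl from either 4-(trifluoromethyl)phenyl or 4-fluorophenyl: the limit of > 322000 nM in this assay, at which 1 of the 4 values shown sits. Also open is how a phenyl ring carrying an amine or a carboxylic acid in place of the fluoro group would read in this assay, and whether such a group would keep the cytotoxicity as weak as it is in compound 4.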